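Moving one methoxy group from compound 2 to compound 3

This account rests on a few compounds, and the source may have more. Where it says the series, first, only, none or still open, it means among the compounds named here.

Measured so far in an ADME assay on NHDF cells (Homo sapiens) for cytotoxicity, read by MTT assay, with a stated time of 72 h; a higher number here means a weaker inhibitor, a lower number a stronger inhibitor:
- compound 1 `COc1ccc(/C=C2\CCC/C(=C\c3ccccc3Cl)C2=O)cc1OC`: 21600 nM
- compound 2 `COc1ccccc1/C=C1\CCC/C(=C\c2ccc(OC)c(OC)c2)C1=O`: 18100 nM

Compound 2, at 18100 nM, lies within the usual scatter of compound 1. Compound 3 `COc1cccc(/C=C2\CCC/C(=C\c3ccc(OC)c(OC)c3)C2=O)c1` has the same atoms joined differently, with 3-methoxyphenyl in place of 2-methoxyphenyl on a double-bonded chain carbon bound to a double-bonded ring carbon. For the measured compounds named here, the only measured step, a 1.2-fold lower number from compound 1 to compound 2 (0.08 log units; within the scatter), put methoxy in place of chloro on an aromatic carbon, a different kind of change, and it stayed within the scatter. No step beyond the scatter is therefore expected in this assay, and the estimated change is a 1.0-fold higher number from compound 2 to compound 3 (0.02 log units; within the scatter). Compound 3 is expected at 19000 nM, with an estimated range from 10000 nM to 35000 nM.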

Compound 3, half-maximal inhibitory concentration: 11600 nM
The estimate for compound 3 lay 1.6-fold (0.21 log units) above the measured number, and the stated range covers the measured number.
By their numbers in this assay, from the lowest: compounds 3, 2 and 1 (each within the scatter of the next).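

In this assay, moving the methoxy group gives (a 1.6-fold lower number from compound 2 to compound 3 (0.19 log units; within the scatter)), so 2-methoxyphenyl and 3-methoxyphenyl cannot be told apart at this double-bonded chain carbon. Putting 3-methoxyphenyl in place of 2-chlorophenyl at the same carbon gives (a 1.9-fold lower number from compound 1 to compound 3 (0.27 log units; within the scatter)), so all three groups seen at this place read alike in this cell test. No measurement shown explains these numbers. Going by these compounds, whether an amine or a carboxylic acid on this aromatic ring, or a longer chain in place of methoxy, would give a step beyond the scatter stays open.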